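The source may report more compounds than this note shows. Statements on the series, on what has been measured and on what is new or still open speak of the compounds shown alone.

Measured in a functional assay on DU-145 cells (Homo sapiens) for cytotoxicity, read by MTT assay, with a stated time of 48 h; on this read-out lower numbers stand for stronger inhibition and higher numbers for weaker inhibition:
compound 1 `Cc1ccc(S(=O)(=O)/N=C(/CCNC2=CC(=O)c3ccccc3C2=O)Nc2ccc(Cl)cc2)cc1` gives 32400 nM
compound 2 `Cc1ccc(S(=O)(=O)/N=C(/CCNC2=CC(=O)c3ccccc3C2=O)Nc2ccc(F)c(F)c2)cc1` gives 12900 nM
compound 3 `COc1cc(N/C(CCNC2=CC(=O)c3ccccc3C2=O)=N\S(=O)(=O)c2ccc(C)cc2)cc(OC)c1OC` gives 9330 nM

Compound 3 carries the lowest of the three numbers. Its separation from compound 1 is clear, a 3.5-fold lower number from compound 1 to compound 3 (0.54 log units; beyond the scatter), whereas the gap to compound 2 is small, a 1.4-fold lower number from compound 2 to compound 3 (0.14 log units; within the scatter), so no order between compound 3 and compound 2 can be claimed. Compound 4 `Cc1ccc(S(=O)(=O)/N=C(/CCNC2=CC(=O)c3ccccc3C2=O)NC2CCCCC2)cc1` differs from compound 3 in one place: cyclohexyl in place of 3,4,5-trimethoxyphenyl on an amine nitrogen. The measured steps that touch this position exchange one aromatic ring for another on the amine nitrogen, a 3.5-fold lower number from compound 1 to compound 3 (0.54 log units; beyond the scatter) and a 2.5-fold lower number from compound 1 to compound 2 (0.40 log units; beyond the scatter), and both were modest. Among the compounds with values here, no measured step replaces the aromatic ring by a saturated one, so this change is not covered by the data. A step of similar or smaller size is expected in this assay, leaning toward a higher number because compound 3 stands at 9330 nM, near the low end of what has been measured. The expected step is a 1.7-fold higher number from compound 3 to compound 4 (0.23 log units; within the scatter). Compound 4 is estimated at 16000 nM, within a range from 5000 nM to 50000 nM.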

Compound 4, half-maximal inhibitory concentration: 16600 nM
The estimate for compound 4 lay 1.0-fold (0.02 log units) below the measured number; the range from low to high includes it.
By their numbers in this assay, from the lowest: compounds 3, 2, 4 and 1 (each within the scatter of the next, the first and the last beyond it).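

In this assay, within the data shown here, the amine nitrogen now carries a saturated ring for the first time, and the cyclohexyl group stays within the scatter of all three aromatic groups (a 1.8-fold higher number from compound 3 to compound 4 (0.25 log units; within the scatter); a 1.3-fold higher number from compound 2 to compound 4 (0.11 log units; within the scatter); a 2.0-fold lower number from compound 1 to compound 4 (0.29 log units; within the scatter)). An aromatic ring on this nitrogen is therefore not needed for activity at this level, and losing the three methoxy oxygens of the 3,4,5-trimethoxyphenyl group produces no readable change. Nothing available explains this tolerance.

As far as these compounds go, whether an open alkyl chain such as n-butyl, or a cyclohexyl ring bearing an amine or a carboxylic acid, would move the number beyond the scatter stays open. So does whether a small group such as methyl on this nitrogen would keep the number in the same range.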